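Removing a chloro from a dichloropurine core: expected effect

The compounds below may be only part of what the source reports. "The series", "measured", "known", "first", "only" and "open" are said of these compounds alone.

Measured compounds:
compound 1 `ClCc1cccc(Cn2cnc3ncnc(Cl)c32)c1`, 63100 nM
compound 2 `ClCc1ccc(Cn2cnc3nc(Cl)nc(Cl)c32)cc1`, 75900 nM
compound 3 `ClCc1cccc(Cn2cnc3nc(Cl)nc(Cl)c32)c1`, 5370 nM

All three were tested in a functional assay on PC-3 cells (Homo sapiens) for cytotoxicity, read by sulforhodamine B assay, with a stated time of 48 h; on this read-out higher numbers stand for lower toxicity in this test and lower numbers for higher toxicity in this test. Compound 3 gives 5370 nM, and compound 1, which carries one chloro fewer on the core, gives 63100 nM. The change between them is hydrogen in place of chloro on an aromatic carbon, and it produced a 12-fold higher number from compound 3 to compound 1 (1.07 log units; beyond the scatter). Compound 2 gives 75900 nM; its two values with compound 1 lie within the usual scatter, so no order can be read between them. Compound 2 and compound 3 are built from the same atoms joined differently, and the difference between the two cores is not broken down here.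

Compound 4 `ClCc1ccc(Cn2cnc3ncnc(Cl)c32)cc1` has not yet been measured in this assay. It stands to compound 2 as compound 1 stands to compound 3: the change is hydrogen in place of chloro on an aromatic carbon, the same change, since the surroundings of the place are described in the same words. If it acts as it did before, compound 4 is expected to give 300000 nM, between 80000 nM and 1200000 nM, a step of a 4.0-fold higher number from compound 2 to compound 4 (0.60 log units; beyond the scatter), because compound 3 to compound 1 showed a 12-fold higher number from compound 3 to compound 1 (1.07 log units; beyond the scatter). This rests on a single earlier instance, and compound 2 already starts from a high number, so the assay may report only a limit.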

Compound 4, concentration lethal to 50% of the cells: 5370 nM
Compound 4: the middle estimate sits 56-fold (1.75 log units) above what was measured; measured number outside the range, below it.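

In this assay, putting hydrogen in place of the chloro on compound 2 gave a 14-fold lower number from compound 2 to compound 4 (1.15 log units; beyond the scatter), so the number fell here, whereas the same change made it rise on the other core, and the two steps clearly disagree: the same change on two cores in this assay, a 12-fold higher number (1.07 log units; beyond the scatter) from compound 3 to compound 1 and a 14-fold lower number (1.15 log units; beyond the scatter) from compound 2 to compound 4, 170-fold (2.22 log units) apart, beyond the scatter of two such steps. This shows that, within these four compounds, neither the size nor the direction of this change carries from one core to the other, so a step measured on one core is a poor guide to the same step on the other. It does not show what causes the disagreement: compound 2 and compound 3 are built from the same atoms joined differently, and two steps cannot say which part of that difference matters, or why.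

The compounds shown leave open what happens on either core when an amine or a methoxy group takes the place of that chloro. They also leave open whether the disagreement persists with a hydroxymethyl group in place of the chloromethyl group.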